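A Furan Replaces Phenyl on an Unresponsive Core

The compounds below may be only part of what the source reports. "The series", "measured", "known", "first", "only" and "open" are said of these compounds alone.

Three compounds share one core and differ only in the group on a saturated ring carbon. Compound 1 `O=C(c1ccncc1)N1N=C(c2cc3ccccc3o2)CC1c1cccc([N+](=O)[O-])c1` carries a 3-nitrophenyl, compound 2 `O=C(c1ccncc1)N1N=C(c2cc3ccccc3o2)CC1c1ccc(Cl)cc1` a 4-chlorophenyl and compound 3 `O=C(c1ccncc1)N1N=C(c2cc3ccccc3o2)CC1c1ccccc1` a plain phenyl. In an ADME assay on Vero cells (Chlorocebus sabaeus) for cytotoxicity, read by MTT assay, with a stated time of 72 h (on this read-out higher numbers stand for weaker inhibition and lower numbers for stronger inhibition), compound 1 reaches only a limit, > 240000 nM. In this assay compound 2 likewise stops at a limit, > 220000 nM. Compound 3 also gives no number in this assay but a limit, > 209000 nM. The step that the two limits leave unreadable from compound 1 to compound 2 cannot be sized because the limit of > 240000 nM in this assay, at which 1 of the 3 values shown sits, and the limit of > 220000 nM in this assay, at which 1 of the 3 values shown sits, are both limits. The same holds for a step that the two limits leave unreadable from compound 1 to compound 3 and for a step that the two limits leave unreadable from compound 2 to compound 3 because the limit of > 209000 nM in this assay, at which 1 of the 3 values shown sits, is a limit as well. Compound 3 thus stands at one of three limits, with no measured number among its neighbours to rank it against.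

Compound 4 `O=C(c1ccncc1)N1N=C(c2cc3ccccc3o2)CC1c1ccco1` keeps the core and makes one change, (furan-2-yl in place of phenyl on a saturated ring carbon). Within the data shown here, none of the measured steps is readable, so none points in a direction for this change. Every group tried on this carbon left its compound at the limit, and compound 4 is expected to stay there too, so the expected step that the limit leaves unreadable from compound 3 to compound 4 is one of no change beyond scatter. The estimate for compound 4 in this assay is 250000 nM, within a range from 100000 nM to 1000000 nM.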

Compound 4, half-maximal inhibitory concentration: > 208000 nM
Compound 4 was reported as a limit; the forecaster's own chance of this, stated with the estimate: 85%; the middle value is on the limit's open side.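

In this assay compound 4 gives only a limit, > 208000 nM. Its steps from compound 1, compound 2 and compound 3 cannot be read. The compounds shown leave open whether any group on this saturated ring carbon would give a measured number in this assay, and how the 3-nitrophenyl, 4-chlorophenyl, phenyl and furan-2-yl compounds rank.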